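Expected Gain When Compound 4 Replaces the Nitrile

This account rests on a few compounds, and the source may have more. Where it says the series, first, only, none or still open, it means among the compounds named here.

Three amides built on one shared core have been measured in a functional assay on HEK293 cells for agonist activity at D(4) dopamine receptor (Homo sapiens), read by FLIPR; on this read-out lower numbers stand for an effect already at smaller amounts and higher numbers for an effect only at larger amounts of compound. Compound 1 `O=C(NCN1CCC(c2cccc[n+]2[O-])CC1)c1ccc(F)c(Cl)c1` gives 63 nM, compound 2 `Cc1cccc(C(=O)NCN2CCC(c3cccc[n+]3[O-])CC2)c1` gives 89 nM, and compound 3 `N#Cc1cccc(C(=O)NCN2CCC(c3cccc[n+]3[O-])CC2)c1` gives 840 nM. Compound 3 therefore stands with the highest number of the three: its nearest neighbour lies a 9.4-fold higher number from compound 2 to compound 3 (0.97 log units; beyond the scatter), and its furthest lies a 13-fold higher number from compound 1 to compound 3 (1.12 log units; beyond the scatter). The remaining pair moved only a 1.4-fold higher number from compound 1 to compound 2 (0.15 log units; within the scatter).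

The unmeasured compound 4 `Cc1cc(C(=O)NCN2CCC(c3cccc[n+]3[O-])CC2)ccc1Cl` differs from compound 3 by 4-chloro-3-methylphenyl in place of 3-cyanophenyl on a carbonyl carbon. Among the measured compounds shown here, two measured steps bear on this change, and both run toward compound 3: from the 3-chloro-4-fluorophenyl of compound 1 and from the 3-methylphenyl of compound 2, each ending in a clearly higher number. Compound 4 carries a chlorine and a methyl on its phenyl, and in compound 1 and compound 2 a chlorine or a methyl on that ring went with the two low numbers. Reversing those steps, a large decrease in the number is expected in this assay, namely a 12-fold lower number from compound 3 to compound 4 (1.08 log units; beyond the scatter). Compound 4 is accordingly estimated at 70 nM, with a range from 25 nM to 200 nM.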

Compound 4, half-maximal effective concentration: 2460 nM
Estimate against measurement, compound 4: 35-fold (1.55 log units) below; measured number above the stated range.
By their numbers in this assay, from the lowest: compounds 1 and 2 (each within the scatter of the next); then compound 3; then compound 4.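

In this assay, chloro in place of hydrogen on an aromatic carbon of the 3-methylphenyl group gives a 28-fold higher number from compound 2 to compound 4 (1.44 log units; beyond the scatter), so one added atom on this ring, which sits on a carbonyl carbon whose other neighbour is an amide-type nitrogen, can shift the number strongly. The 4-chloro-3-methylphenyl group also compares poorly with the 3-chloro-4-fluorophenyl group, at a 39-fold higher number from compound 1 to compound 4 (1.59 log units; beyond the scatter), and with the 3-cyanophenyl group, at a 2.9-fold higher number from compound 3 to compound 4 (0.47 log units; beyond the scatter), so the nitrile no longer marks the top of the series, and a chlorine on this ring does not by itself go with a low number, as compound 1 carries one and compound 4 carries one at opposite ends of the four. Nothing at hand gives a measured reason for any of these steps.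

On these data alone, whether the rise belongs to chloro as such or to its place on the ring stays open. So does whether a fluoro, a methoxy group or an amine in that same place on the 3-methylphenyl group would raise the number as far as chloro does.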